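Dropping the nitro group from compound 3

This account rests on a few compounds, and the source may have more. Where it says the series, first, only, none or still open, it means among the compounds named here.

Three compounds have been measured in a functional assay on U-87MG ATCC cells (Homo sapiens) for cytotoxicity, read by MTT assay, with a stated time of 48 h; a lower number here means a stronger inhibitor, a higher number a weaker inhibitor:
Compound 1, `C/C(=N/NC(=S)Nc1ccccc1I)c1ccccn1`, gives 6.1 nM.
Compound 2, `C/C(=N/NC(=S)Nc1cccc([N+](=O)[O-])c1)c1ccccn1`, gives 69 nM.
Compound 3, `C/C(=N/NC(=S)Nc1ccc([N+](=O)[O-])cc1)c1ccccn1`, gives 160 nM.

Compound 3 stands highest of the three numbers and is therefore the weakest inhibitor among them; its nearest neighbour is compound 2, a modest distance below and beyond the usual scatter, while compound 1 lies far below it. Compound 4, `C/C(=N/NC(=S)Nc1ccccc1)c1ccccn1`, has not yet been measured. It differs from compound 3 in one place: hydrogen in place of nitro on an aromatic carbon. Within the data shown here, no measured pair shows this change, so its effect cannot be read from the data. The other two values, compound 2 at 69 nM and compound 1 at 6.1 nM, both lie below compound 3. Compound 4 is expected to land below compound 3, with the step of a 4.0-fold lower number from compound 3 to compound 4 (0.60 log units; beyond the scatter) estimated as a moderate gain in this assay. Compound 4 is estimated at 40 nM, with a range from 10 nM to 200 nM.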

Compound 4, half-maximal inhibitory concentration: 1.4 nM
Estimate against measurement, compound 4: 29-fold (1.46 log units) above; measured number below the stated range.
By their numbers in this assay, from the lowest: compound 4; then compound 1; then compound 2; then compound 3.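

Replacing nitro with hydrogen brings a large gain at both nitro-bearing compounds shown (a 110-fold lower number from compound 3 to compound 4 (2.06 log units; beyond the scatter); a 49-fold lower number from compound 2 to compound 4 (1.69 log units; beyond the scatter)), so neither nitro placement comes close to bare hydrogen in this assay. Iodo also gives way to hydrogen, though by a modest step (a 4.4-fold lower number from compound 1 to compound 4 (0.64 log units; beyond the scatter)), and compound 4 is therefore the strongest of the four: each of the three substituents shown gives a higher number than hydrogen, and no compound here goes against this. Nothing available here bears on why this is so.

From the compounds shown here alone, whether a fluoro, a methyl or an amine on the aromatic ring would match hydrogen remains open.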